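Dropping the Chloro Group from Compound 2

The source may hold more compounds than are shown below. What is called first, only, known or untested is meant among the compounds shown, and "the series" means these compounds.

Compound 2 `O=C1c2ccccc2N(Cc2ccccc2)S(=O)(=O)N1Cc1ccc(Cl)cc1` is one of three close relatives tested in a functional assay on HEL cells (Homo sapiens) for inhibition; a higher number here means that more compound is tolerated, a lower number that less compound is tolerated. In this assay compound 2 gives 121000 nM, the higher of the two plain numbers known. Compound 3 `O=C(OCOCN1c2ccccc2C(=O)N(Cc2ccccc2)S1(=O)=O)c1ccccc1` gives 37000 nM. Compound 1 `O=C1c2ccccc2N(COCc2ccccc2)S(=O)(=O)N1Cc1ccccc1` reaches only the limit of this assay, > 122000 nM, so no number is known for it. Going by the values given here, the one measured step, an at least 3.2-fold lower number from compound 1 to compound 3 (0.51 log units; beyond the scatter), concerns a benzoyloxy in place of a phenyl on a saturated chain carbon bound to an oxygen, not the group that changes here. Compound 4 `O=C1c2ccccc2N(Cc2ccccc2)S(=O)(=O)N1Cc1ccccc1` differs from compound 2 by hydrogen in place of chloro on an aromatic carbon. Among the compounds with values here, no measured step touches this chloro group, so nothing in hand points in either direction, and no shift beyond the scatter is expected. Compound 4 is therefore expected to give about 130000 nM in this assay, somewhere between 50000 nM and 300000 nM. That expectation amounts to a 1.1-fold higher number from compound 2 to compound 4 (0.03 log units; within the scatter), with a fair chance that only a limit is reported.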

Compound 4, half-maximal cytotoxic concentration: > 200000 nM
Compound 4: only a limit was reported; the forecaster's own chance of this, stated with the estimate: 40%; middle value at least 1.5-fold (0.18 log units) from the limit.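

Going by these compounds alone, this is the first look at the chloro group on the 4-chlorobenzyl of compound 2, and in this assay the change to the plain benzyl of compound 4 gives an at least 1.6-fold higher number from compound 2 to compound 4 (0.21 log units; that floor lies within the scatter). Only that floor is known, and it lies within the scatter, but nothing here suggests that the chloro group is needed for cells to tolerate this compound as well as they do. The value of compound 4 is a limit and not a plain number, so the full size of this step stays unknown: the limit of > 200000 nM in this assay, at which 1 of the 4 values shown sits.

The step between compound 1 and compound 4 joins two limits and cannot be read. From the compounds shown here alone, whether a fluoro group, a methoxy group or an amine in place of the chloro group would move the number stays open.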